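Swapping thiophenyl for chlorophenyl on the sulfonyl sulfur

The source may report more compounds than this note shows. Statements on the series, on what has been measured and on what is new or still open speak of the compounds shown alone.

For the measured compounds named here, compound 2 `CC1=NC(c2cn(S(=O)(=O)c3cccs3)c3ccc(C)cc23)CN1` is the only compound with a numerical result here: in an assay on isolated protein for inhibition of kallikrein-7 (Homo sapiens), read by fluorescence, with stated times of 10 min and 30 min (a higher number here means a weaker inhibitor, a lower number a stronger inhibitor), compound 2 gives 11000 nM. Compound 1 `CC1=NC(c2cn(S(=O)(=O)c3cccc(Cl)c3)c3ccccc23)CN1` reaches only a limit of this assay, > 30000 nM. Compound 3 `CC1=NC(c2cn(S(=O)(=O)c3cccc(Cl)c3)c3ccc(C)cc23)CN1` carries 3-chlorophenyl in place of thiophen-2-yl on a sulfonyl sulfur. Because compound 1, which also bears 3-chlorophenyl on the sulfonyl sulfur, sits at the limit of > 30000 nM in this assay, at which 1 of the 2 values shown sits, compound 3 is expected to lose potency beyond the scatter, a step of a 2.7-fold higher number from compound 2 to compound 3 (0.44 log units; beyond the scatter) toward weaker inhibition. Compound 3 is estimated at 30000 nM in this assay, within 10000 nM to 100000 nM, with a real chance that only a limit is reported.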

Compound 3, half-maximal inhibitory concentration: 30000 nM
Estimate against measurement, compound 3: no gap at the digits printed; the measured number falls inside the stated range.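

In this assay the exchange on the sulfonyl sulfur now has a readable size: 3-chlorophenyl in place of thiophen-2-yl gives a 2.7-fold higher number from compound 2 to compound 3 (0.44 log units; beyond the scatter) as a modest step toward weaker inhibition. Compound 1 reaches only a limit, > 30000 nM. Methyl in place of hydrogen on an aromatic carbon gives a number no higher from compound 1 to compound 3 (the limit leaves the size open) so the size of this step cannot be read.

The compounds shown leave open how an unsubstituted phenyl or a 3-methoxyphenyl on the sulfonyl sulfur would compare with thiophen-2-yl. They also leave open whether the loss follows the six-membered ring or the chlorine.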